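Swapping 4-pentylphenyl for phenethyl on a triple-bonded carbon

The source may hold more compounds than are shown below. What is called first, only, known or untested is meant among the compounds shown, and "the series" means these compounds.

In an ADME assay on WI-38 cells (Homo sapiens) for cytotoxicity, read by MTT assay, with a stated time of 3 days (on this read-out higher numbers stand for weaker inhibition and lower numbers for stronger inhibition), compound 1 `O=C1c2ccccc2C(=O)N1C/C=C\Cn1cc(C#Cc2ccc(Br)cc2)c(=O)[nH]c1=O` gives 47000 nM as its measured value. Compound 2 `CCCCCc1ccc(C#Cc2cn(C/C=C\CN3C(=O)c4ccccc4C3=O)c(=O)[nH]c2=O)cc1` gives > 100000 nM as a limit of the assay, not a number. Compound 3 `O=C1c2ccccc2C(=O)N1C/C=C\Cn1cc(C#CCCc2ccccc2)c(=O)[nH]c1=O` carries phenethyl in place of 4-pentylphenyl on a triple-bonded carbon. Among the measured compounds shown here, the only measured step that bears on this is an at least 2.1-fold higher number from compound 1 to compound 2 (0.32 log units; beyond the scatter) with pentyl in place of bromo on an aromatic carbon, so it is a loose guide. The estimated move is an at least 1.5-fold lower number from compound 2 to compound 3 (0.18 log units; that floor lies within the scatter) and no large change is expected. Compound 3 is expected near 65000 nM with an estimated range from 25000 nM to 150000 nM in this assay as the test of this estimate.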

Compound 3, half-maximal inhibitory concentration: > 100000 nM
Compound 3 was reported as a limit; the forecaster's own chance of this, stated with the estimate: 35%; middle value at least 1.5-fold (0.18 log units) away from the limit.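

Compound 3 gives > 100000 nM in this assay, a limit of the assay and not a number. The 4-bromophenyl group of compound 1 can therefore be replaced on this triple-bonded carbon by phenethyl as well as by 4-pentylphenyl, and phenethyl gives an at least 2.1-fold higher number from compound 1 to compound 3 (0.32 log units; beyond the scatter). The step between the two replacements cannot be read, since both results stop at the same ceiling: the limit of > 100000 nM in this assay, at which 2 of the 3 values shown sit.

Which of the two replacements weakens cytotoxicity more remains open. So does whether a group such as an amine or a carboxylic acid at this place would bring the number back down.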